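Propyl to tert-butyl on the hydroxy-acid side chain

This account rests on a few compounds, and the source may have more. Where it says the series, first, only, none or still open, it means among the compounds named here.

Measured so far:
compound 1, `O=C(NCc1cc(Cl)ccc1-n1cnnn1)[C@@H]1C[C@@H]2C[C@@H]2N1C(=O)[C@H](O)Cc1ccccn1`, 17 mL.min-1.g-1
compound 2, `CCCC[C@@H](O)C(=O)N1N=CC[C@H]1C(=O)NCc1cc(Cl)ccc1-n1cnnn1`, < 12 mL.min-1.g-1
compound 3, `O=C(NCc1cc(Cl)ccc1-n1cnnn1)[C@@H]1C[C@H]2C[C@H]2N1C(=O)[C@H](O)c1cccc(F)c1`, 32 mL.min-1.g-1

In an ADME assay on liver for metabolic stability, with Liver microsome (Homo sapiens) as the target, read by LC-MS, using microsomes (a higher number here means faster removal of the compound, a lower number slower removal), compound 1 gives 17 mL.min-1.g-1 and compound 3 gives 32 mL.min-1.g-1. For compound 2 the result is only a limit, < 12 mL.min-1.g-1, so compound 2 stands at the low end of what this assay reports; this is the limit of < 12 mL.min-1.g-1 in this assay, at which 1 of the 3 values shown sits, and not a number. Compound 2 therefore sits at or under the values of compound 1 and compound 3, but how far under cannot be said.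

Compound 4, `CC(C)(C)C[C@@H](O)C(=O)N1N=CC[C@H]1C(=O)NCc1cc(Cl)ccc1-n1cnnn1`, differs from compound 2 in one place: tert-butyl in place of propyl on a saturated chain carbon, two bonds along the chain from a carbonyl carbon and an oxygen on a saturated carbon. Among the measured compounds no pair differs in one place, so no measured step exists against which this change can be weighed.

The change adds one carbon to the side chain and alters its branching, and nothing measured here ties such a change to a shift in this assay. Compound 4 is therefore expected to stay close to compound 2, with a step of an at least 1.1-fold higher number from compound 2 to compound 4 (0.06 log units; that floor lies within the scatter) that lies within the usual scatter or only slightly beyond it. Compound 4 is estimated at 14 mL.min-1.g-1, with a range from 6 mL.min-1.g-1 to 32 mL.min-1.g-1, and a fair chance that this assay again reports only a limit.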

Compound 4, intrinsic clearance in microsomes: 22 mL.min-1.g-1
Compound 4: middle estimate off by 1.6-fold (0.20 log units), on the low side, and the stated range covers the measured number.
By their numbers in this assay, from the lowest: compounds 1, 4 and 3 (each within the scatter of the next). At a limit, below all of these: compound 2.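

This pair is the only one shown that differs in one place, so it gives the sole reading of a change at this position: in this assay, tert-butyl in place of propyl, on a saturated chain carbon, two bonds along the chain from a carbonyl carbon and an oxygen on a saturated carbon, comes with an at least 1.8-fold higher number from compound 2 to compound 4 (0.26 log units; that floor lies within the scatter). Compound 4, which carries the tert-butyl, reads as a number, 22 mL.min-1.g-1. The step remains a floor that lies within the usual scatter, so a real rise is allowed but not established, because the result for compound 2 is a limit and not a number: the limit of < 12 mL.min-1.g-1 in this assay, at which 1 of the 4 values shown sits.

Still open, from the compounds shown here alone, is how far compound 2 truly lies from compound 4, and whether the same change would read alike on the core of compound 1 or compound 3. Also open, going by these compounds, is how a longer chain or a carboxylic acid at this place would read in this assay.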